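The compounds below may be only part of what the source reports. "The series", "measured", "known", "first", "only" and "open" are said of these compounds alone.

Of the compounds shown here, three built on one shared core have been tested so far in a functional assay on HeLa cells (Homo sapiens) for antiproliferative activity, read by MTT assay, with a stated time of 72 h (a higher number here means a weaker inhibitor, a lower number a stronger inhibitor), as a starting point. Compound 1 (`COc1cc(-c2nccn2C)cc(OC)c1OC`) gives > 100000 nM here, which is a limit of the assay and not a number. Compound 2 (`COc1cc(-c2nccn2Cc2ccccc2)cc(OC)c1OC`) gives > 100000 nM here, again a limit and not a number. Only compound 3 (`COc1cccc(-n2ccnc2-c2cc(OC)c(OC)c(OC)c2)c1`) has a true number, 11000 nM in this series, so it is the one firm reference point.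

Compound 4 (`COc1cc(-c2nccn2-c2ccc(Br)cc2)cc(OC)c1OC`) differs from compound 3 in one place, with 4-bromophenyl in place of 3-methoxyphenyl on an aromatic nitrogen. Among the measured compounds shown here, two measured steps concern that nitrogen. Placing 3-methoxyphenyl there gave an at least 9.0-fold lower number from compound 1 to compound 3 (0.95 log units; beyond the scatter) and also an at least 9.0-fold lower number from compound 2 to compound 3 (0.95 log units; beyond the scatter) in place of benzyl, and each of these sizes is only a minimum. For the measured compounds named here, compound 4 keeps a phenyl ring on that nitrogen, but no measured step changes what such a ring carries, so the data point in neither direction. The expectation therefore stays anchored on compound 3 at 11000 nM with a wide margin on both sides. The estimated step is a 1.4-fold lower number from compound 3 to compound 4 (0.14 log units; within the scatter) and no shift beyond the scatter is expected. For compound 4 the expected value is 8000 nM within an estimated range of 1500 nM to 50000 nM in this assay for now.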

Compound 4, half-maximal inhibitory concentration: 3300 nM
Estimate against measurement, compound 4: 2.4-fold (0.38 log units) above; the measured number falls inside the stated range.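

In this assay, among the compounds shown here, the new result shows that the group carried by a phenyl ring on this aromatic nitrogen can shift the number: replacing 3-methoxyphenyl with 4-bromophenyl gives a 3.3-fold lower number from compound 3 to compound 4 (0.52 log units; beyond the scatter), whereas the earlier steps only showed what happens when such a ring replaces methyl or benzyl. Against those two smaller-scale starting points the change is now large, with an at least 30-fold lower number from compound 2 to compound 4 (1.48 log units; beyond the scatter) and an at least 30-fold lower number from compound 1 to compound 4 (1.48 log units; beyond the scatter), so the choice of group at this nitrogen clearly matters in this short series. Both of those sizes are only minimums, and the true gaps could be wider, because each starting compound sits at a limit of the assay and not at a number: the limit of > 100000 nM in this assay, at which 2 of the 4 values shown sit.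

The swap alters both the group on the phenyl ring and where that group sits, so the compounds shown leave open which of the two accounts for the step; a 3-bromophenyl or a 4-methoxyphenyl group would separate them. Also open, from the compounds shown here alone, is how a plain phenyl ring, or a phenyl ring carrying an amine or a carboxylic acid, would behave at this nitrogen.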